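The compounds below may be only part of what the source reports. "The series", "measured", "known", "first", "only" and "open" are said of these compounds alone.

Measured compounds:
- Compound 1 `COc1ccc(-c2ccnc(NC(=O)c3ccc(F)cc3)c2)cc1`: > 100000 nM, a limit of the assay
- Compound 2 `COc1ccc(-c2cnc(NC(=O)c3cccc(C#N)c3)n2C)cc1`: > 100000 nM, a limit of the assay
- Compound 3 `CCCC(=O)Nc1ncc(-c2ccc(OC)cc2)n1C`: > 100000 nM, a limit of the assay

All three were tested in a toxicity assay on THP-1 cells (Homo sapiens) for inhibition; a lower number here means that less compound is tolerated, a higher number that more compound is tolerated. None of them gave a number; each result is only a limit, meaning the cells tolerated every concentration tried. Compound 3 therefore stands at the limit of > 100000 nM in this assay, at which 3 of the 3 values shown sit, and nothing separates it from the two other compounds. Among the compounds with values here, the one step between measured compounds, a step that the two limits leave unreadable from compound 2 to compound 3, cannot be read, since both its ends are limits.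

Compound 4 `COc1ccc(-c2cnc(NC(=O)c3ccc(C#N)cc3)n2C)cc1` differs from compound 3 by 4-cyanophenyl in place of propyl on a carbonyl carbon. Within the data shown here, no measured step gives the size of such a change, so the only guide is the limit of > 100000 nM in this assay, at which 3 of the 3 values shown sit, where all three values sit. The expected step is a step that the limit leaves unreadable from compound 3 to compound 4, none beyond the scatter. Compound 4 is therefore expected to give 150000 nM. For compound 4 the estimated range runs from 60000 nM to 400000 nM, with the result most likely reported again as a limit.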

Compound 4, half-maximal cytotoxic concentration: > 100000 nM
Compound 4: no number, only a limit; the forecaster's own chance of this, stated with the estimate: 85%; the middle value does not contradict the limit.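

No new step can be read from compound 2 or compound 3 to compound 4, because each result is only a limit: the limit of > 100000 nM in this assay, at which 4 of the 4 values shown sit.

The compounds shown leave open at what concentration, if any, the amide changes among them would separate their tolerance in this assay.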